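The source may hold more compounds than are shown below. What is called first, only, known or untested is meant among the compounds shown, and "the series" means these compounds.

Working notes on the series.

Two compounds have a number in a functional assay on MDA-MB-468 cells (Homo sapiens) for inhibition, read by sulforhodamine B assay, with a stated time of 48 h; on this read-out lower numbers stand for stronger inhibition of growth and higher numbers for weaker inhibition of growth. Compound 1 `Cc1cc(O)cc(-c2nn(CC#N)cc2-c2ccnc(-c3ccc(Oc4ccccc4)cc3)c2)c1` gives 3850 nM in this assay. Within the data shown here, compound 2 `COc1cc(C)cc(-c2nn(CC#N)cc2-c2ccnc(-c3ccc(N(C)C)cc3)c2)c1` gives 635 nM in this assay, the lower of the two numbers; the gap from compound 1 to compound 2 is beyond the scatter, but the two structures differ in more than one place, so the two values show only that compound 2 grows the cells less at a lower concentration. Among the measured compounds shown here, no single-point step between measured compounds exists in this set.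

Compound 3 `Cc1cc(O)cc(-c2nn(CC#N)cc2-c2ccnc(-c3ccc(N(C)C)cc3)c2)c1` has not been measured. It differs from compound 2 by hydrogen in place of methyl on an oxygen on an aromatic ring. For the measured compounds named here, no measured pair isolates this change, so the direction of the step is open; the expectation is a step from compound 2 to compound 3 of about a 1.4-fold higher number from compound 2 to compound 3 (0.15 log units; within the scatter), which may sit within the scatter, with a small weakening considered somewhat more likely than a gain. Compound 3 is therefore estimated at 900 nM in this assay, expected to fall between 300 nM and 3000 nM.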

Compound 3, concentration for total growth inhibition: 4020 nM
For compound 3 the middle estimate is 4.5-fold (0.65 log units) below the measured one; measured number above the stated range.
By their numbers in this assay, from the lowest: compound 2; then compounds 1 and 3 (each within the scatter of the next).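

On the 3-methoxy-5-methylphenyl group, the change from methoxy to hydroxy now has a measured step in this assay: a 6.3-fold higher number from compound 2 to compound 3 (0.80 log units; beyond the scatter), beyond the scatter, so the methyl on this oxygen matters for the read-out in this pair. With the hydroxy kept, dimethylamino in place of phenoxy on an aromatic carbon gives a 1.0-fold higher number from compound 1 to compound 3 (0.02 log units; within the scatter), within the scatter, so this pair does not separate the two groups at this read-out. No measurement is available that bears on why the methoxy and hydroxy compounds differ.

Among these compounds, it remains open whether the step from methoxy to hydroxy has the same size when phenoxy takes the place of dimethylamino, since the single measured pair for this change carries dimethylamino. On these data alone, it is also open whether an ethoxy group, a longer alkoxy chain or an amine in place of the methoxy would keep a number near that of compound 2 at 635 nM, or would move it beyond the scatter in either direction.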